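Cytotoxicity notes: demethylation at the aromatic amine, two cores

This account rests on a few compounds, and the source may have more. Where it says the series, first, only, none or still open, it means among the compounds named here.

Of the compounds shown here, three have been tested in an ADME assay on MT4 cells (Homo sapiens) for cytotoxicity, read by MTT assay, with a stated time of 4 days; a lower number here means that less compound is tolerated, a higher number that more compound is tolerated. Compound 1 `CNc1nc(Nc2ccc(C#N)cc2)nc(Oc2cccc3ccccc23)n1` gives 30300 nM. Compound 2 `N#Cc1ccc(Nc2nc(N)nc(Oc3cccc4ccccc34)n2)cc1` carries hydrogen in place of methyl on a nitrogen on an aromatic ring relative to compound 1, and in this assay compound 2 gives 39100 nM. The step of a 1.3-fold higher number from compound 1 to compound 2 (0.11 log units; within the scatter) shows that the two numbers sit within the usual scatter, so no order between compound 1 and compound 2 is read from them.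

Compound 3 `CNc1nc(Nc2ccc(C#N)cc2)nc(Oc2ccc3cc(Br)ccc3c2Br)n1` belongs to a second core; how its core differs from the core of compound 1 is not broken down here. In this assay compound 3 gives 92800 nM, the highest of the three numbers, with compound 2 nearest and compound 1 furthest, both gaps beyond the scatter.

Compound 4 `N#Cc1ccc(Nc2nc(N)nc(Oc3ccc4cc(Br)ccc4c3Br)n2)cc1` is not yet measured. It differs from compound 3 by hydrogen in place of methyl on a nitrogen on an aromatic ring, the same change that takes compound 1 to compound 2, at the same kind of place. The expectation for compound 4 rests on that one measured step, a 1.3-fold higher number from compound 1 to compound 2 (0.11 log units; within the scatter), which stayed within the scatter, and on the value of compound 3, 92800 nM, as the starting point. The step expected is a 1.2-fold higher number from compound 3 to compound 4 (0.07 log units; within the scatter), which would again be within the scatter. Compound 4 is therefore estimated at 110000 nM, with the expected range from 55000 nM to 220000 nM.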

Compound 4, half-maximal cytotoxic concentration: 244000 nM
Beside the measured number, compound 4's estimate is 2.2-fold (0.35 log units) below it, outside the stated range (above it).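

In this assay, the change from methylamino to amino gives a 2.6-fold higher number from compound 3 to compound 4 (0.42 log units; beyond the scatter), so on the core of compound 3 this step is beyond the scatter, though it is modest in size. Set beside the step on the core of compound 1, it does not form a separate result: the same change on two cores in this assay, a 1.3-fold higher number (0.11 log units; within the scatter) from compound 1 to compound 2 and a 2.6-fold higher number (0.42 log units; beyond the scatter) from compound 3 to compound 4, 2.0-fold (0.31 log units) apart, within the scatter of two such steps. The two cores are therefore compatible with a single step size for this change, but one pair per core does not establish that size, and it neither shows that the core of compound 3 responds more strongly nor gives any reason for the gap between the steps.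

The compounds shown leave open whether the step would hold on a third core, since any reading of transfer rests on these two pairs alone. They also leave open how this assay would respond to other groups on the same nitrogen, such as ethyl, a longer chain or acetyl, as only methylamino and amino appear here.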